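The source may hold more compounds than are shown below. What is called first, only, known or untested is meant among the compounds shown, and "the series" means these compounds.

Measured compounds:
- Compound 1 `COc1cc(Oc2cc(N)nc(Nc3ccc(C#N)cc3)n2)ccc1-c1ccc(C#N)cc1`: 12900 nM
- Compound 2 `Cc1cc(-c2cccc(F)c2)cc(C)c1Oc1cc(N)nc(Nc2ccc(C#N)cc2)n1`: 24700 nM

In a toxicity assay on MT4 cells (Homo sapiens) for cytotoxicity, read by MTT assay (a lower number here means that less compound is tolerated, a higher number that more compound is tolerated), compound 2 gives 24700 nM, and compound 1 gives 12900 nM. These two values lie within the usual scatter of each other, so compound 2 stands level with compound 1 on the numbers available, and neither can be ranked against the other.

The next compound is compound 3 `Cc1cc(-c2cccc(Cl)c2)cc(C)c1Oc1cc(N)nc(Nc2ccc(C#N)cc2)n1`. It differs from compound 2 in a single place: chloro in place of fluoro on an aromatic carbon. This puts chloro in place of fluoro on an aromatic carbon, meta to a large group, turning the 3-fluorophenyl into a 3-chlorophenyl.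

Among the measured compounds shown here, no two measured compounds differ in one place only, so the data hold no direct precedent for this exchange. For such a small replacement, only a modest shift in this assay is expected, with no change beyond the scatter and at most a slight drift toward a lower number. The expected change is a 1.2-fold lower number from compound 2 to compound 3 (0.09 log units; within the scatter), which stays within the scatter.

For compound 3 the estimated value is 20000 nM, with an expected range of 8000 nM to 50000 nM.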

Compound 3, half-maximal cytotoxic concentration: 22300 nM
Compound 3: the middle estimate sits 1.1-fold (0.05 log units) below what was measured; low and high end bracket the measured number.
By their numbers in this assay, from the lowest: compounds 1, 3 and 2 (each within the scatter of the next).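

In this assay, among the compounds shown here, the exchange of fluoro for chloro on an aromatic carbon, meta to a large group, gives a 1.1-fold lower number from compound 2 to compound 3 (0.04 log units; within the scatter) and provides the first pair that differs in one place only. At this position, then, turning the 3-fluorophenyl into a 3-chlorophenyl leaves the number within the scatter, and compound 2 and compound 3 stand level in this assay. For the compounds shown here, that finding covers only this one exchange of one halogen for another, on a ring that otherwise stays the same, and it cannot be carried over to compound 1, which differs from both in more than one place.

The compounds shown leave open whether this position would stay level with a group of a different kind in place of the halogen, such as a methoxy group, a nitrile, an amine or a carboxylic acid, and whether the same holds for chloro placed elsewhere on that ring. Nothing in the data shown offers an explanation for the level result.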